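Nitro substitution on the rhodanine series: expectation for compound 3

A few compounds are considered here, and "the series" means these few. Any claim that something is new, unique, unknown or untested is made for them only; others in the source may bear on it.

In an assay on isolated protein for inhibition of Alpha glucosidase (Homo sapiens), read by spectrophotometry, with stated times of 15 min and 30 min (a lower number here means a stronger inhibitor, a higher number a weaker inhibitor), compound 1 `O=C1NC(=O)/C(=C/c2cc([N+](=O)[O-])ccc2OCN2C(=O)c3ccccc3C2=O)S1` gives 50500 nM. Compound 2 `O=C1NC(=S)S/C1=C\c1ccccc1OCN1C(=O)c2ccccc2C1=O` differs from compound 1 in its core and lacks the nitro group. For compound 2 this assay reports only a limit, > 100000 nM; it is the limit of the assay and not a number, so compound 2 stands at the weak end of what has been measured here, and the limit of > 100000 nM in this assay, at which 1 of the 2 values shown sits, records this. Going by the values given here, no step between two measured compounds with a single change exists, so the size of any change has to be estimated rather than read.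

Compound 3 `O=C1NC(=S)S/C1=C\c1cc([N+](=O)[O-])ccc1OCN1C(=O)c2ccccc2C1=O` is not yet measured. It is made from compound 2 by the change (nitro in place of hydrogen on an aromatic carbon). Compound 1, which carries the same nitro group on a different core, gives a measurable 50500 nM in this assay, which suggests that the nitro group is compatible with some measurable inhibition. The step from compound 2 to compound 3 is therefore expected to go toward stronger inhibition, estimated as an at least 1.4-fold lower number from compound 2 to compound 3 (0.15 log units; that floor lies within the scatter), though a limit remains a real possibility. For compound 3 the estimate in this assay is 70000 nM, expected to fall between 25000 nM and 200000 nM.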

Compound 3, half-maximal inhibitory concentration: 35800 nM
Compound 3: middle estimate off by 2.0-fold (0.29 log units), on the high side, within the range that was stated.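

In this assay, going by these compounds alone, nitro in place of hydrogen on an aromatic carbon, meta to a group of 8 heavy atoms and para to a large group, gives an at least 2.7-fold lower number from compound 2 to compound 3 (0.44 log units; beyond the scatter), the first step that isolates a single group at this position and shows that this change alone moves the read-out beyond the scatter. With nitro in place, exchanging the core of compound 1 for the core of compound 3 gives a 1.4-fold lower number from compound 1 to compound 3 (0.15 log units; within the scatter), so the two cores cannot be told apart in this assay when both carry this group. The nitro step is a floor and not a full size, as compound 2 stands at a limit of the assay: the limit of > 100000 nM in this assay, at which 1 of the 3 values shown sits.

The compounds shown leave open whether an amine, a carboxylic acid or a methoxy group in the same place would give a step of similar size, or whether nitro is particular in this respect. They also leave open how large the nitro step is on the core of compound 1, and whether nitro elsewhere on the same aromatic ring would do the same.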